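Swapping a hydroxyphenyl substituent from ortho to para

The compounds below may be only part of what the source reports. "The series", "measured", "known", "first", "only" and "open" are said of these compounds alone.

Compound 1 `Oc1ccc(-c2cc(-c3ccco3)cc(-c3ccc(O)cc3)n2)cc1` in a functional assay on HCT-15 cells (Homo sapiens) for cytotoxicity, read by CCK-8 assay (on this read-out lower numbers stand for stronger inhibition and higher numbers for weaker inhibition), gives 14000 nM.
Compound 2 `Oc1ccc(-c2cc(-c3ccoc3)cc(-c3ccc(O)cc3)n2)cc1` in this assay gives 1530 nM.
Compound 3 `Oc1ccc(-c2cc(-c3ccccn3)cc(-c3ccccc3O)n2)cc1` in this assay gives only a limit, > 50000 nM.

Among the three measured compounds, compound 3 is the one with no number: it sits at the limit of > 50000 nM in this assay, at which 1 of the 3 values shown sits, so only a limit is known for it. Compound 4 `Oc1ccc(-c2cc(-c3ccccn3)cc(-c3ccc(O)cc3)n2)cc1` differs from compound 3 by 4-hydroxyphenyl in place of 2-hydroxyphenyl on an aromatic carbon; the change sits on an aromatic carbon of a six-membered aromatic ring with 1 nitrogen, next to the ring nitrogen, meta to a 4-hydroxyphenyl group and meta to a pyridin-2-yl group. For the measured compounds named here, the single measured step, a 9.2-fold lower number from compound 1 to compound 2 (0.96 log units; beyond the scatter), concerns a different position and a different group, so no measured step bears directly on the change from compound 3 to compound 4. Compound 1 and compound 2, which both carry two 4-hydroxyphenyl groups, give measurable numbers, whereas compound 3, with one 2-hydroxyphenyl, gives only a limit. On this slim basis compound 4 is expected at 12000 nM, within 2500 nM to 50000 nM. That expectation corresponds to an at least 4.1-fold lower number from compound 3 to compound 4 (0.61 log units; beyond the scatter), though with considerable uncertainty.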

Compound 4, half-maximal inhibitory concentration: > 50000 nM
Compound 4 ended at the assay's limit (the forecaster's own chance of this, stated with the estimate: 30%); at least 4.1-fold (0.61 log units) between middle value and limit.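

Compound 4 gives > 50000 nM in this assay, which is a limit of the assay and not a number. With 4-hydroxyphenyl on both sides of the shared core, pyridin-2-yl in place of a furan gives an at least 32-fold higher number from compound 2 to compound 4 (1.51 log units; beyond the scatter) and an at least 3.5-fold higher number from compound 1 to compound 4 (0.55 log units; beyond the scatter), so 4-hydroxyphenyl at this place does not by itself bring a measurable number when pyridin-2-yl is present. The step between compound 3 and compound 4 cannot be read, because both stand at the same limit: the limit of > 50000 nM in this assay, at which 2 of the 4 values shown sit.

Going by these compounds, whether swapping 2-hydroxyphenyl for 4-hydroxyphenyl changes the read-out at all therefore stays open, and a 2-hydroxyphenyl analogue of compound 2, keeping its furan-3-yl group, could give a readable comparison. How a 3-hydroxyphenyl or 4-aminophenyl group would behave at this place is also unknown.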